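The source may report more compounds than this note shows. Statements on the series, on what has been measured and on what is new or still open speak of the compounds shown alone.

Measured compounds in a functional assay on SK-MEL-5 cells (Homo sapiens) for inhibition, read by sulforhodamine B assay, with a stated time of 48 h, tested at 10 uM; on this read-out higher numbers stand for more inhibition at the one concentration tested (going by the name of the read-out) and lower numbers for less inhibition:
compound 1 `c1ccc(-c2cn3ccnc3c(-c3ccc4ncn(C5CCCCC5)c4c3)n2)cc1`: 36.5%
compound 2 `O=Cc1ccc(-c2cn3ccnc3c(-c3ccc4ncn(C5CCCCC5)c4c3)n2)cc1`: 56.5%
compound 3 `Brc1ccc(-c2cn3ccnc3c(-c3ccc4ncn(C5CCCCC5)c4c3)n2)cc1`: 23.6%

Compound 3 stands lowest of the three numbers; its nearest neighbour is compound 1, separated by a number 12.9 percentage points lower from compound 1 to compound 3 (beyond the scatter), and the furthest is compound 2, separated by a number 32.9 percentage points lower from compound 2 to compound 3 (beyond the scatter). Compound 4 `COc1ccccc1-c1cn2ccnc2c(-c2ccc3ncn(C4CCCCC4)c3c2)n1` differs from compound 3 by 2-methoxyphenyl in place of 4-bromophenyl on an aromatic carbon. Within the data shown here, no measured step puts a methoxy group in place of bromo, so the bearing of the measured steps is indirect. Both steps that introduced bromo, a number 12.9 percentage points lower from compound 1 to compound 3 (beyond the scatter) and a number 32.9 percentage points lower from compound 2 to compound 3 (beyond the scatter), lowered the read-out, while the step putting formyl in place of hydrogen, a number 20 percentage points higher from compound 1 to compound 2 (beyond the scatter), raised it. Removal of bromo and entry of 2-methoxyphenyl is therefore expected to give a modest rise, a number 16.4 percentage points higher from compound 3 to compound 4 (beyond the scatter). Compound 4 is estimated at 40%, with a range from 22% to 58%.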

Compound 4, a percentage reported as inhibition, at one concentration (the size of the read-out at that concentration, not a potency): 8.94%
Beside the measured number, compound 4's estimate is 31.1 percentage points above it; the whole stated range lies above it.
By their numbers in this assay, from the lowest: compound 4; then compound 3; then compound 1; then compound 2.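

In this assay, 2-methoxyphenyl at this position of the shared core gives the lowest number of the four compounds, with a number 14.7 percentage points lower from compound 3 to compound 4 (beyond the scatter), a number 27.6 percentage points lower from compound 1 to compound 4 (beyond the scatter) and a number 47.6 percentage points lower from compound 2 to compound 4 (beyond the scatter). A lower number therefore comes with bromo and with methoxy alike, and among the substituted compounds only compound 2 goes against this by standing above compound 1. Nothing at hand explains these differences.

Open, as far as these compounds go, is whether the fall follows the methoxy group itself or its place on the phenyl ring. Also open, from the compounds shown here alone, is whether 4-aminophenyl or 4-carboxyphenyl would stand with 4-formylphenyl or with 4-bromophenyl.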